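Removing the drawn configuration from a hydroxybutyl chain

This account rests on a few compounds, and the source may have more. Where it says the series, first, only, none or still open, it means among the compounds named here.

In a functional assay on MCF7 cells (Homo sapiens) for antiproliferative activity, read by MTT assay, with a stated time of 24 h, tested at 25 uM (on this read-out higher numbers stand for a weaker effect at the one concentration tested and lower numbers for a stronger effect), two compounds sharing a tetrabromobenzotriazole-type core have been measured. Compound 1 `OC(CCn1nc2c(Br)c(Br)c(Br)c(Br)c2n1)c1ccc(F)cc1` gives 101% in this assay, and compound 2 `C[C@H](O)CCn1nc2c(Br)c(Br)c(Br)c(Br)c2n1` gives 102% in this assay. These two numbers lie within the usual scatter of each other, so compound 2 cannot be separated from compound 1 on this read-out: both sit near the level at which the treated cells behave like untreated ones at the single concentration tested.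

Compound 3 `CC(O)CCn1nc2c(Br)c(Br)c(Br)c(Br)c2n1` is next. It differs from compound 2 only in how one stereocentre is drawn: the two compounds have the same atoms and bonds; at least one stereo element is drawn with a configuration in one of them and without one in the other: 1 of 1 stereo elements differ; a stereocentre at a saturated chain carbon is drawn S in compound 2 and without a configuration in compound 3. Compound 3 keeps every atom and bond of compound 2, and nothing leaves or enters the molecule.

Since the two measured compounds already agree within the scatter, and the change to compound 3 alters no atom or bond, the account expects no step beyond the scatter in this assay from compound 2 to compound 3, the expected step being a number 1 percentage points lower from compound 2 to compound 3 (within the scatter). For compound 3 the value in this assay is estimated at 101%, with a likely range from 91% to 111%.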

Compound 3, a percentage reported as activity, at one concentration (the size of the read-out at that concentration, not a potency): 102%
Beside the measured number, compound 3's estimate is 1 percentage points below it, and the stated range covers the measured number.
By their numbers in this assay, from the lowest: compounds 1, 2 and 3 (each within the scatter of the next).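

In this assay, the stereocentre at a saturated chain carbon can now be read as a single change, and it gives no change at the digits printed from compound 2 to compound 3 (within the scatter) in this comparison. The swap of methyl in place of 4-fluorophenyl on a saturated chain carbon can also now be read on its own, and it gives a number 1 percentage points higher from compound 1 to compound 3 (within the scatter) on this read-out, a one-place comparison that compounds 1 and 2 alone did not offer. Neither change therefore separates the compounds at the single concentration tested, and the sole structural distinction within the stereochemical pair is this: the fact that one of compounds 2 and 3 is drawn with a defined configuration and the other without, at the place where they differ

From the compounds shown here alone, whether the undefined drawing of compound 3 stands for one form or a mixture remains open, as does the effect of the opposite configuration at this stereocentre. Going by these compounds, it also remains open whether an amine or a carboxylic acid in place of the methyl or 4-fluorophenyl group, or a longer chain, would move the read-out away from the level shared by these three compounds.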